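The compounds below may be only part of what the source reports. "The series", "measured", "known", "first", "only" and "open" are said of these compounds alone.

Measured so far, each in an assay on isolated protein for inhibition of thiosulfate sulfurtransferase (Homo sapiens), with a stated time of 60 min, in the absence of a further agent; a lower number here means a stronger inhibitor, a higher number a weaker inhibitor:
Compound 1 `COc1ccc(Br)cc1C(=O)Nc1ccccc1` gives > 100000 nM, which is a limit of the assay and not a number.
Compound 2 `COc1ccccc1C(=O)Nc1cccc(Cl)c1` gives > 100000 nM, again a limit of the assay.
Compound 3 `COc1c(Br)cc(Br)cc1C(=O)Nc1cccc(Cl)c1` gives > 100000 nM, once more a limit of the assay.

Compound 3 therefore stands nowhere in particular among the numbers shown: no compound has a measured value, and all three results sit at the limit of > 100000 nM in this assay, at which 3 of the 3 values shown sit. Compound 4 `COc1ccc(Br)cc1C(=O)Nc1cccc(Cl)c1` differs from compound 3 by hydrogen in place of bromo on an aromatic carbon. Going by the values given here, no pair of measured compounds differs in a single place, so no measured step is available to say what this change does in this assay. Among the compounds with values here, the expected step from compound 3 to compound 4 is a step that the limit leaves unreadable from compound 3 to compound 4, which is no step beyond the scatter of the assay, because every value so far rests at the limit of > 100000 nM in this assay, at which 3 of the 3 values shown sit. Compound 4 is expected to give about 150000 nM in this assay, within a range from 30000 nM to 1000000 nM, and most likely the result will again be only a limit rather than a number.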

Compound 4, half-maximal inhibitory concentration: > 100000 nM
Compound 4 was reported as a limit; the forecaster's own chance of this, stated with the estimate: 85%; the middle value does not contradict the limit.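

Going by these compounds alone, no step from compound 1, compound 2 or compound 3 to compound 4 can be read, because all four results are limits of the assay and not numbers: the limit of > 100000 nM in this assay, at which 4 of the 4 values shown sit. The compounds shown leave open which change to the shared core, if any, would give a measurable value in this assay.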